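The source may report more compounds than this note shows. Statements on the series, on what has been measured and on what is new or still open speak of the compounds shown alone.

Measured so far in an in vitro ADME assay on microsomes (Homo sapiens) for metabolic stability; on this read-out higher numbers stand for a longer-lived compound and lower numbers for a shorter-lived compound
compound 1 `CCc1nc(NC(CC)CC)c(OC)nc1-c1ccc(OC(F)F)cc1Cl` at 2 h
compound 2 `CCC(CC)Nc1nc(OC)c(-c2ccc(Cl)cc2Cl)nc1C` at 0.933 h

Compound 2 holds the lower of the two numbers, and its gap to compound 1 lies beyond the scatter. Compound 3 `CCC(CC)Nc1nc(C)c(-c2ccc(Cl)cc2Cl)nc1C` is still unmeasured. The change methyl in place of methoxy on an aromatic carbon sits next to the ring nitrogen. Among the measured compounds shown here, no measured pair shows this change, so the expectation rests on compound 2 at 0.933 h alone, and no step beyond the scatter is expected in this assay here. The estimate means a 1.2-fold higher number from compound 2 to compound 3 (0.07 log units; within the scatter) as the expected step. For compound 3 the estimate is 1.1 h with 0.5 h to 2.4 h as its expected range.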

Compound 3, half-life: 0.483 h
Estimate against measurement, compound 3: 2.3-fold (0.36 log units) above; the whole stated range lies above it.
By their numbers in this assay, from the lowest: compounds 3 and 2 (each within the scatter of the next); then compound 1.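

In this assay, methyl in place of methoxy on the aromatic carbon next to the ring nitrogen gives a 1.9-fold lower number from compound 2 to compound 3 (0.29 log units; within the scatter). Among the compounds shown here, this single pair gives the first direct reading of the change, and at this position it shows no step beyond the scatter. Nothing available bears on a cause for this result. Going by these compounds, whether an ethoxy group, an amine or a hydroxyl on this carbon would read differently in this assay remains open. Also open, on these data alone, is whether the same change would read alike with the difluoromethoxy-bearing aryl group of compound 1.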